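Methyl in Place of Fluoro: A Permeability Expectation

The source may report more compounds than this note shows. Statements on the series, on what has been measured and on what is new or still open speak of the compounds shown alone.

Of the compounds shown here, two of one shared core have been measured. Compound 1 `COc1ccc(NC2=NCCC3(CCCCC3)S2)cc1` gives 1.11 10^-6 cm/s in a physicochemical assay for permeability; on this read-out higher numbers stand for higher permeability and lower numbers for lower permeability. Compound 2 `Fc1ccc(NC2=NCCC3(CCCCC3)S2)cc1Cl` gives 7.36 10^-6 cm/s in this assay, the higher of the two numbers, with compound 1 clearly below it. Compound 3 `Cc1ccc(NC2=NCCC3(CCCCC3)S2)cc1Cl` is not yet measured. It differs from compound 2 by methyl in place of fluoro on an aromatic carbon. Among the compounds with values here, no measured pair shows this change, so the step of a 1.2-fold higher number from compound 2 to compound 3 (0.06 log units; within the scatter) is expected to stay within the usual scatter, leaning if anything slightly upward. Compound 3 is therefore estimated at 8.5 10^-6 cm/s, within a range from 4 10^-6 cm/s to 17 10^-6 cm/s.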

Compound 3, apparent permeability: 23.9 10^-6 cm/s
Beside the measured number, compound 3's estimate is 2.8-fold (0.45 log units) below it, outside the stated range (above it).
By their numbers in this assay, from the lowest: compound 1; then compound 2; then compound 3.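

Within the data shown here, on an aromatic carbon ortho to a chloro group, methyl in place of fluoro is the only single-place change that can be read in this assay, and it gives a 3.2-fold higher number from compound 2 to compound 3 (0.51 log units; beyond the scatter). This position is therefore not indifferent to which of these two small groups it carries, although that reading rests on one pair alone. No measurement shown bears on what lies behind the step. The compounds shown leave open how an amine, a carboxylic acid or a longer chain such as propyl would read at this place. They also leave open whether methyl in place of fluoro would give a similar step without the chloro group.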